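A few compounds are considered here, and "the series" means these few. Any claim that something is new, unique, unknown or untested is made for them only; others in the source may bear on it.

Within the data shown here, compound 2 `COc1cccc(C#Cc2ccc3c(n2)CCN(C2CCCC2)C3=O)c1` is the only compound with a numerical result in a functional assay on HEK293 cells for positive allosteric modulation of metabotropic glutamate receptor 5 (Homo sapiens), read by FLIPR and calcium flux (a higher number here means that more compound is needed for the effect, a lower number that less compound is needed), where compound 2 gives 462 nM. Compound 1 `CC(C)N1CCc2nc(C#Cc3cccnc3)ccc2C1=O` is reported in this assay as "not active" (no number reported). Compound 3 `O=C1c2ccc(C#Cc3cccnc3)nc2CCN1C1CCCC1` differs from compound 2 by pyridin-3-yl in place of 3-methoxyphenyl on a triple-bonded carbon. Among the measured compounds shown here, no measured pair traces this change on its own, but compound 1, which carries the same pyridin-3-yl group on a different core nitrogen substituent, gave "not active" (no number reported) in this assay, so a weakening step beyond the scatter is expected for compound 3, with a real chance that no number is reported. Compound 3 is therefore estimated at 2000 nM in this assay, within a range of 600 nM to 8000 nM. That estimate would mean a step of a 4.3-fold higher number from compound 2 to compound 3 (0.64 log units; beyond the scatter).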

Compound 3, half-maximal effective concentration: 748 nM
Beside the measured number, compound 3's estimate is 2.7-fold (0.43 log units) above it, within the range that was stated.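

In this assay pyridin-3-yl on a triple-bonded carbon takes the place of 3-methoxyphenyl with a 1.6-fold higher number from compound 2 to compound 3 (0.21 log units; within the scatter) and a numerical result is kept. Compound 1 gives "not active" (no number reported) and compound 3 gives 748 nM with the same pyridin-3-yl, so that group alone does not decide whether a number is reported. As far as these compounds go, what a pyridin-4-yl or a carboxylic acid would give on the same triple-bonded carbon stays open. Nothing at hand explains why the two groups give results within the scatter of each other.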